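Fluoro Added Beside the Nitrile of Compound 3

The compounds below may be only part of what the source reports. "The series", "measured", "known", "first", "only" and "open" are said of these compounds alone.

Measured compounds:
compound 1, `NS(=O)(=O)CC(=O)NCCSc1nonc1/C(=N/O)Nc1cccc(C(F)F)c1`, 17 nM
compound 2, `NS(=O)(=O)CC(=O)NCCSc1nonc1/C(=N/O)Nc1cccc(Cl)c1`, 10 nM
compound 3, `N#Cc1cccc(N/C(=N\O)c2nonc2SCCNC(=O)CS(N)(=O)=O)c1`, 44 nM

In an assay for inhibition of Indoleamine 2,3-dioxygenase 1 (Homo sapiens), read by fluorescence, with a stated time of 24 h (on this read-out lower numbers stand for stronger inhibition and higher numbers for weaker inhibition), compound 3 gives the highest number of the three. Its nearest neighbour is compound 1: a 2.6-fold higher number from compound 1 to compound 3 (0.41 log units; beyond the scatter). Against compound 2 the gap is wider: a 4.4-fold higher number from compound 2 to compound 3 (0.64 log units; beyond the scatter). Compound 1 and compound 2 sit close to each other: a 1.7-fold lower number from compound 1 to compound 2 (0.23 log units; within the scatter).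

Compound 4, `N#Cc1cc(N/C(=N\O)c2nonc2SCCNC(=O)CS(N)(=O)=O)ccc1F`, keeps the whole of compound 3 and adds one atom: fluoro in place of hydrogen on an aromatic carbon. Within the data shown here, none of the measured steps bears directly on this change; each of them swaps the group that stands on the ring for another, while here a fluoro enters ortho to a cyano group with everything else kept. The measured steps show that changes on this ring move this assay only modestly, so a step of similar or smaller size is expected.

Compound 4 is therefore expected to land near compound 3, with a 1.3-fold lower number from compound 3 to compound 4 (0.10 log units; within the scatter), at an estimated 35 nM within 15 nM to 90 nM.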

Compound 4, half-maximal inhibitory concentration: 39 nM
Beside the measured number, compound 4's estimate is 1.1-fold (0.05 log units) below it; the range from low to high includes it.
By their numbers in this assay, from the lowest: compounds 2 and 1 (each within the scatter of the next); then compounds 4 and 3 (each within the scatter of the next).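

In this assay the entry of fluoro ortho to a cyano group and para to a large group gives no change that stands out from the scatter (a 1.1-fold lower number from compound 3 to compound 4 (0.05 log units; within the scatter)), so this aromatic carbon accepts the added atom without a visible cost or gain. The 3-cyano-4-fluorophenyl group also stays behind the two other rings beyond the scatter (a 3.9-fold higher number from compound 2 to compound 4 (0.59 log units; beyond the scatter); a 2.3-fold higher number from compound 1 to compound 4 (0.36 log units; beyond the scatter)), which means the fluoro does not close the gap that compound 3 showed against them. Nothing measured here offers an explanation for this flat step.

The compounds shown leave open whether the same fluoro would be equally silent on the 3-chlorophenyl or 3-(difluoromethyl)phenyl ring. They also leave open whether a methoxy group or an amine at this carbon would move the number further.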